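A few compounds are considered here, and "the series" means these few. Any claim that something is new, unique, unknown or untested is made for them only; others in the source may bear on it.

Three measured compounds share one core and differ only in the group on the five-membered ring. Compound 2 `Nc1ncnn2c([C@@H]3O[C@H](CO)[C@@H](O)[C@H]3O)cc(C#Cc3ccccc3)c12` bears a 2-phenylethynyl group there, and compound 1 `Nc1ncnn2c([C@@H]3O[C@H](CO)[C@@H](O)[C@H]3O)cc(C#Cc3ccc(F)cc3)c12` differs from it by fluoro in place of hydrogen on an aromatic carbon. Compound 3 `Nc1ncnn2c([C@@H]3O[C@H](CO)[C@@H](O)[C@H]3O)cc(-c3ccccc3F)c12` differs from compound 2 by 2-fluorophenyl in place of 2-phenylethynyl on an aromatic carbon. In a functional assay on K562 cells (Homo sapiens) for antiproliferative activity, with a stated time of 72 h (on this read-out lower numbers stand for stronger inhibition and higher numbers for weaker inhibition), compound 2 gives > 100000 nM, which is a limit of the assay and not a number. In this assay compound 1 likewise gives only a limit, > 100000 nM. Compound 3 also reaches only a limit in this assay, > 100000 nM. Accordingly a step that the two limits leave unreadable from compound 2 to compound 1, a step that the two limits leave unreadable from compound 1 to compound 3 and a step that the two limits leave unreadable from compound 2 to compound 3, because of the limit of > 100000 nM in this assay, at which 3 of the 3 values shown sit. Compound 4 `Nc1ncnn2c([C@@H]3O[C@H](CO)[C@@H](O)[C@H]3O)cc(-c3ccc(F)cc3F)c12` has not been measured; it differs from compound 3 by fluoro in place of hydrogen on an aromatic carbon, the same kind of change as from compound 2 to compound 1, although the place is now also meta to a fluoro group. The earlier step of this kind left no readable size. Compound 4 is expected to give about 150000 nM in this assay, most likely again a limit. The step this estimate means is expected to be a step that the limit leaves unreadable from compound 3 to compound 4.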

Compound 4, half-maximal inhibitory concentration: 69700 nM
The estimate for compound 4 lay 2.2-fold (0.33 log units) above the measured number, within the range that was stated.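

In this assay compound 3 gives > 100000 nM, which is a limit of the assay and not a number. Fluoro in place of hydrogen on the 2-fluorophenyl group gives an at least 1.4-fold lower number from compound 3 to compound 4 (0.15 log units; that floor lies within the scatter), and the exchanges of the ethynyl groups give an at least 1.4-fold lower number from compound 2 to compound 4 (0.15 log units; that floor lies within the scatter) and an at least 1.4-fold lower number from compound 1 to compound 4 (0.15 log units; that floor lies within the scatter), so compound 4 alone carries a number, but each of these floors stays within the scatter and none shows a real difference. Whether the change carries over from the core of compound 2 to that of compound 3 cannot be said, because the same change from compound 2 to compound 1 cannot be read, and neither can the other steps among the first three compounds: the limit of > 100000 nM in this assay, at which 3 of the 4 values shown sit.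

The compounds shown leave open how far below this limit the series can go at all. They also leave open whether a chloro, a methoxy, an amine or a carboxylic acid in place of the added fluoro would give a number clearly apart from that of compound 4.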